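Chloro for Hydroxy on the Benzoyl Ring of a Quinolinone

A few compounds are considered here, and "the series" means these few. Any claim that something is new, unique, unknown or untested is made for them only; others in the source may bear on it.

Of the compounds shown here, two sharing one core have been measured in a functional assay on HT-29 cells (Homo sapiens) for cytotoxicity, read by sulforhodamine B assay, with a stated time of 24 h; on this read-out higher numbers stand for weaker inhibition of growth and lower numbers for stronger inhibition of growth. Compound 1 `COc1ccc(C(=O)/C=C/c2cc3ccccc3[nH]c2=O)cc1` gives 3670 nM in this assay. Compound 2 `O=C(/C=C/c1cc2ccccc2[nH]c1=O)c1ccc(O)cc1` carries hydroxy where compound 1 carries methoxy. In this assay compound 2 gives 3610 nM. Among the measured compounds shown here, the only step between measured compounds, a 1.0-fold lower number from compound 1 to compound 2 (0.01 log units; within the scatter), shows that exchanging hydrogen for methyl on the ring oxygen made no difference beyond the scatter. Compound 2 therefore stands at the lower of the two numbers, but its distance to compound 1 is within the scatter, so no order between the two can be read.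

Compound 3 `O=C(/C=C/c1cc2ccccc2[nH]c1=O)c1ccc(Cl)cc1` differs from compound 2 by chloro in place of hydroxy on an aromatic carbon. For the measured compounds named here, no measured step involves a chloro group, so the one step seen, which changed a substituent on the same position without effect, bears only loosely on this change. The account expects a step of a 1.4-fold lower number from compound 2 to compound 3 (0.14 log units; within the scatter) from compound 2 to compound 3, not beyond the scatter. Compound 3 is estimated at 2600 nM, with a range from 900 nM to 7500 nM.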

Compound 3, concentration for 50% growth inhibition: 3840 nM
Compound 3: middle estimate off by 1.5-fold (0.17 log units), on the low side; the measured number falls inside the stated range.
By their numbers in this assay, from the lowest: compounds 2, 1 and 3 (each within the scatter of the next).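

Chloro in place of hydroxy on this aromatic carbon, para to a large group, gives a 1.1-fold higher number from compound 2 to compound 3 (0.03 log units; within the scatter) in this assay and chloro in place of methoxy gives a 1.0-fold higher number from compound 1 to compound 3 (0.02 log units; within the scatter), so neither exchange moves the number beyond the scatter. The earlier step changed only what sat on the ring oxygen, whereas these two steps remove that oxygen altogether, and hydroxy, with 1 hydrogen-bond donor and 1 hydrogen-bond acceptor, gives way to chloro, with 0 of either, without a difference that can be read. Across these three compounds, then, the position has taken an oxygen-linked group and a halogen alike with no readable difference, though no measurement is at hand that could speak to the reason for this.

The compounds shown leave open whether an amine, a carboxylic acid or a longer chain such as butoxy on this same carbon would give a number beyond the scatter of these three. They also leave open whether changes elsewhere on the shared core, such as replacing the amide hydrogen with methyl, would prove equally silent.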